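This account rests on a few compounds, and the source may have more. Where it says the series, first, only, none or still open, it means among the compounds named here.

Among the compounds with values here, compound 1, with the structure `CCCS(=O)(=O)Nc1ccc(F)c(C(=O)c2n[nH]c3ncc(-c4cccc(Cl)c4)cc23)c1F`, is one of two compounds measured in an assay for binding affinity to dual specificity mitogen-activated protein kinase kinase 4 (Homo sapiens), read by KINOMEscan, tested at 100 nM (a lower number here means a stronger effect, a higher number a weaker effect of the compound at the concentration tested), and in this assay compound 1 gives 40%, the higher of the two numbers. The other measured compound is compound 2, with the structure `CCCS(=O)(=O)Nc1ccc(F)c(C(=O)c2n[nH]c3ncc(-c4ccc(O)cc4)cc23)c1F`; in this assay compound 2 gives 0.75%. Within the data shown here, the single measured step, 4-hydroxyphenyl in place of 3-chlorophenyl on an aromatic carbon, gave a number 39.3 percentage points lower from compound 1 to compound 2 (beyond the scatter).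

Compound 3, with the structure `CCCS(=O)(=O)Nc1ccc(F)c(C(=O)c2n[nH]c3ncc(-c4ccc(C)c(C)c4)cc23)c1F`, has not yet been measured in this assay. It differs from compound 1 as follows: 3,4-dimethylphenyl in place of 3-chlorophenyl on an aromatic carbon

Among the measured compounds shown here, the only measured step, from compound 1 to compound 2, exchanges the 3-chlorophenyl for a 4-hydroxyphenyl and does not involve a 3,4-dimethylphenyl, so no measured step bears directly on the change to compound 3. With nothing to anchor it, the step in this assay is estimated to be small, likely within the scatter, so that the expected change is a number 5 percentage points lower from compound 1 to compound 3 (within the scatter). Compound 3 is therefore expected to give about 35%, within a range from 10% to 75%.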

Compound 3, a percentage reported as activity, at one concentration (the size of the read-out at that concentration, not a potency): 20%
The estimate for compound 3 lay 15 percentage points above the measured number, within the range that was stated.
By their numbers in this assay, from the lowest: compound 2; then compound 3; then compound 1.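

In this assay, a number 20 percentage points lower from compound 1 to compound 3 (beyond the scatter) when the 3-chlorophenyl gives way to the 3,4-dimethylphenyl, so the 4-hydroxyphenyl is no longer the only replacement at this position that lowers the number. The entering 3,4-dimethylphenyl is counted with no hydrogen-bond donors or acceptors, just like the 3-chlorophenyl it replaces, and the shift still lies beyond the scatter. Within the data shown here, the 4-hydroxyphenyl keeps the lowest number of the three, since the change to the 3,4-dimethylphenyl gives a number 19.3 percentage points higher from compound 2 to compound 3 (beyond the scatter) and so places the three groups at separate levels, with no compound here going against that order. Nothing available explains why these groups at this position differ.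

Which of the two methyl groups carries the step remains open, and a 4-methylphenyl or a 3-methylphenyl on the shared core would separate them. As far as these compounds go, it is also open whether a 3-hydroxyphenyl, or a phenyl ring bearing an amine or a carboxylic acid, would fall close to compound 2 or closer to compound 1 at this position.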